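A Single Stereocentre Redrawn on Compound 1

A few compounds are considered here, and "the series" means these few. Any claim that something is new, unique, unknown or untested is made for them only; others in the source may bear on it.

In a functional assay on A549 cells (Homo sapiens) for cytotoxicity, read by sulforhodamine B assay (on this read-out higher numbers stand for weaker inhibition of growth and lower numbers for stronger inhibition of growth), compound 1 `COC1=C(Br)[C@H](O)[C@@]2(C=C1Br)CC(C(=O)NCCCCCNC(=O)C1=NO[C@]3(C=C(Br)C(=O)[C@@H](Br)[C@@H]3O)C1)=NO2` gives 7100 nM. Among the compounds with values here, this is the higher of the two numbers known so far, which makes it the weaker growth inhibitor of the pair. Compound 2 `O=C(NCCCCCNC(=O)C1=NO[C@]2(C=C(Br)C(=O)[C@@H](Br)[C@@H]2O)C1)C1=NO[C@]2(C=C(Br)C(=O)[C@@H](Br)[C@@H]2O)C1` gives 2900 nM, and the gap between the two lies beyond the usual scatter. Within the data shown here, these two compounds do not differ in just one place, so their values offer no clean single-change step.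

Compound 3 `COC1=C(Br)[C@H](O)[C@@]2(C=C1Br)CC(C(=O)NCCCCCNC(=O)C1=NO[C@]3(C=C(Br)C(=O)[C@H](Br)[C@@H]3O)C1)=NO2` has not yet been measured. Its relation to compound 1 is a narrow one: the two compounds have the same atoms and bonds and differ only in configuration as drawn: 1 of 5 stereo elements differ; a stereocentre at a saturated ring carbon is drawn S in compound 1 and R in compound 3. Nothing leaves and nothing enters, and a stereocentre at a saturated ring carbon is simply drawn S in compound 1 and R in compound 3. Among the measured compounds shown here, no measured pair shows what such an inversion does here. The expectation in this assay is therefore no step beyond the scatter, with no firm direction, and the range is kept wide. The expected step is a 1.2-fold lower number from compound 1 to compound 3 (0.07 log units; within the scatter). The estimated value for compound 3 is 6000 nM, with an expected range of 2500 nM to 14000 nM.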

Compound 3, concentration for total growth inhibition: 8700 nM
For compound 3 the middle estimate is 1.5-fold (0.16 log units) below the measured one; the measured number falls inside the stated range.
By their numbers in this assay, from the lowest: compound 2; then compounds 1 and 3 (each within the scatter of the next).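

The stereocentre at a saturated ring carbon now has a measured step of its own: in this assay, redrawing it from S to R comes to a 1.2-fold higher number from compound 1 to compound 3 (0.09 log units; within the scatter). Within the data shown here, the earlier compounds held no pair differing in one place, so this is the first direct reading of what the drawn configuration at this carbon means here, and it shows that this assay does not separate the two forms. The comparison is a clean one, with nothing leaving and nothing entering, and its reading rests on a single point: the fact that compounds 1 and 3 differ only in the configuration as drawn.

This one pair speaks only for this stereocentre on this scaffold, so the compounds shown leave open whether inverting any of the other stereo elements would also stay within the scatter, and whether the same holds on cells other than those of this assay. They also leave open how the number would respond to a structural change rather than a stereochemical one, such as a longer chain in place of the shared one or an amine on the shared core.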